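The compounds below may be only part of what the source reports. "The series", "measured", "known", "first", "only" and "open" are said of these compounds alone.

In an ADME assay on THP-1 cells (Homo sapiens) for cytotoxicity (on this read-out higher numbers stand for lower toxicity in this test and lower numbers for higher toxicity in this test), three compounds have been measured:

compound 1 `N#Cc1ccc2nc(-c3ccccn3)c(Nc3ccc(F)cc3)n2c1`: > 50000 nM, which is a limit of the assay rather than a number.
compound 2 `Fc1ccc(Nc2c(-c3ccccn3)nc3ccc(C(F)(F)F)cn23)cc1`: > 50000 nM, again a limit of the assay.
compound 3 `N#Cc1ccn2c(Nc3ccc(F)cc3)c(-c3ccccn3)nc2c1`: > 50000 nM, also a limit of the assay.

Compound 2 comes from compound 1 by the change (trifluoromethyl in place of cyano on an aromatic carbon), and the step that the two limits leave unreadable from compound 1 to compound 2 cannot be sized, since (the limit of > 50000 nM in this assay, at which 3 of the 3 values shown sit). Compound 4 `Fc1ccc(Nc2c(-c3ccccn3)nc3cc(C(F)(F)F)ccn23)cc1` comes from compound 3 by the same kind of change, (trifluoromethyl in place of cyano on an aromatic carbon); the place differs in that it is opposite the ring nitrogen rather than two atoms from the ring nitrogen. The difference between the two cores of compound 1 and compound 3 is not broken down here. Compound 4 is expected to stay at the limit as well, an expected step that the limit leaves unreadable from compound 3 to compound 4, because of the limit of > 50000 nM in this assay, at which 3 of the 3 values shown sit. The estimate for compound 4 in this assay is 80000 nM.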

Compound 4, half-maximal cytotoxic concentration: 23700 nM
For compound 4 the middle estimate is 3.4-fold (0.53 log units) above the measured one; measured number outside the range, below it.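

In this assay, trifluoromethyl in place of cyano on the core of compound 3 gives an at least 2.1-fold lower number from compound 3 to compound 4 (0.32 log units; beyond the scatter), so on this core the change can be seen. That step is only a minimum, as compound 3 sits at a limit of the assay rather than at a number. The same change on the core of compound 1 cannot be read, so nothing shows whether the step carries over from one core to the other: the limit of > 50000 nM in this assay, at which 3 of the 4 values shown sit.

The compounds shown leave open whether other groups at this place, such as an amine or a carboxylic acid, would also lower the number in this assay. They also leave open how far above compound 4 the true value of compound 3 lies.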